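Swapping Hydroxy for Acetamido: Expected Lipophilicity of Compound 4

This account rests on a few compounds, and the source may have more. Where it says the series, first, only, none or still open, it means among the compounds named here.

Measured so far in a physicochemical assay for lipophilicity; on this read-out higher numbers stand for higher lipophilicity and lower numbers for lower lipophilicity:
Compound 1 `CC(=O)Nc1ccc(OC(=S)Nc2ccc(Oc3ccc(C(Cl)(Cl)Cl)cc3)cc2)cc1` gives 6.16.
Compound 2 `Oc1ccc(OC(=S)Nc2ccc(Oc3ccc(C(F)(F)F)cc3)cc2)cc1` gives 6.11.
Compound 3 `O=[N+]([O-])c1ccc(Oc2ccc(NC(=S)Oc3ccc(O)cc3)cc2)cc1` gives 5.01.

Compound 3 stands lowest of the three numbers in this assay. Its nearest neighbour is compound 2, whose value lies higher by a margin beyond the usual scatter; compound 1 lies further away still. For the measured compounds named here, the only single-point step among the measured compounds is a number 1.10 log units lower from compound 2 to compound 3 (beyond the scatter), a large drop tied to a nitro replacing a trifluoromethyl.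

Compound 4 `CC(=O)Nc1ccc(OC(=S)Nc2ccc(Oc3ccc([N+](=O)[O-])cc3)cc2)cc1` is not yet measured. It differs from compound 3 in one place: acetamido in place of hydroxy on an aromatic carbon. Going by the values given here, no measured step describes this particular swap. Compounds 1 and 2 do carry acetamido and hydroxy at that position, but they also differ elsewhere, so their two values can only be noted as close to one another, not read as a step. On that thin basis, and on the general character of the two groups, the change is expected to move the number by only a modest amount, estimated as a number 0.16 log units lower from compound 3 to compound 4 (within the scatter), somewhat downward. Compound 4 is therefore expected to come out near 4.85, with a plausible range from 4.35 to 5.35.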

Compound 4, partition coefficient: 4.81
The estimate for compound 4 lay 0.04 log units above the measured number; the range from low to high includes it.
By their numbers in this assay, from the lowest: compounds 4 and 3 (each within the scatter of the next); then compounds 2 and 1 (each within the scatter of the next).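

In this assay, for the compounds shown here, the swap at this position can now be read directly for the first time: replacing hydroxy (1 heavy atom) with acetamido (4 heavy atoms) on the aromatic carbon gives a number 0.20 log units lower from compound 3 to compound 4 (within the scatter) and so makes no measurable difference in this pair, even though the group is larger. The new compound also adds a second nitro swap on an aromatic carbon, with nitro in place of trichloromethyl giving a number 1.35 log units lower from compound 1 to compound 4 (beyond the scatter) and with acetamido present throughout, which sits alongside the earlier swap of nitro for trifluoromethyl, a number 1.10 log units lower from compound 2 to compound 3 (beyond the scatter), seen with hydroxy present. Across these compounds, then, the large changes come with the nitro swaps, while the change from hydroxy to acetamido stays small, and nothing available explains either observation.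

As far as these compounds go, the comparison of hydroxy with acetamido rests on a single pair carrying nitro, so it remains open whether the two groups would also stay this close with trifluoromethyl or trichloromethyl in the molecule. From the compounds shown here alone, it is equally open how an amine, a carboxylic acid or a longer chain would behave on the same aromatic carbon.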